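This account rests on a few compounds, and the source may have more. Where it says the series, first, only, none or still open, it means among the compounds named here.

Measured compounds:
compound 1, `CCCCCCCCc1ccc(CCC(N)(CO)C(=O)O)cc1`, > 10 mg/kg in a functional assay on the whole organism (spleen, spleen) with Rattus norvegicus as the target; a higher number here means that more compound is needed for the effect, a lower number that less compound is needed
compound 2, `CCCCCCCCc1ccc(CCC(N)CO)cc1`, > 10 mg/kg
compound 3, `CCCCCCCOc1ccc(CCC(N)(CC)CO)cc1`, 0.044 mg/kg

The values of compound 1 and compound 2 are each a limit of this assay, not a number; both sit at the limit of > 10 mg/kg in this assay, at which 2 of the 3 values shown sit. Among the compounds with values here, compound 3 therefore stands as the only compound with a number in this assay. The step from compound 1 to compound 2, a step that the two limits leave unreadable from compound 1 to compound 2, is a change elsewhere in the molecule and bears no readable size on the present case.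

Compound 4, `CCCCCCCOc1ccc(CCC(N)(CO)CCC)cc1`, has not yet been measured. It differs from compound 3 by methyl in place of hydrogen on a saturated chain carbon, three bonds along the chain from an amine nitrogen. Within the data shown here, no measured step covers this change. The expectation is therefore a step of a 1.4-fold higher number from compound 3 to compound 4 (0.13 log units; within the scatter) not beyond the scatter, and compound 4 is estimated at 0.06 mg/kg, between 0.015 mg/kg and 0.25 mg/kg.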

Compound 4, dose for 50% inhibition: 7.3 mg/kg
Compound 4: middle estimate off by 120-fold (2.09 log units), on the low side; the whole stated range lies below it.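

In this assay, going from ethyl to propyl, with methyl in place of hydrogen on a saturated chain carbon, three bonds along the chain from an amine nitrogen, is a 170-fold higher number from compound 3 to compound 4 (2.22 log units; beyond the scatter). The earlier compounds shown here offered no readable step at this position, and this one shows that the length of this chain can weigh heavily on the dose needed. Nothing shown gives a cause for the size of this step. 

Going by these compounds, whether a butyl chain here would raise the number further remains open. So does whether a methyl here would give a lower number than ethyl.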